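The source may report more compounds than this note shows. Statements on the series, on what has been measured and on what is new or still open speak of the compounds shown alone.

Compound 1, with the structure `CCN(C)CCCOc1ccc2cc(NC(=O)c3ccc(O)c(CC=C(C)C)c3)c(=O)oc2c1C`, serves as the point of departure. In a functional assay on MCF7 cells (Homo sapiens) for antiproliferative activity (on this read-out higher numbers stand for weaker inhibition and lower numbers for stronger inhibition), compound 1 gives 2190 nM, the highest of the three numbers at hand. Its nearest neighbour is compound 2, with the structure `CC(C)=CCc1cc(C(=O)Nc2cc3ccc(OCCCNCC(N)=O)c(C)c3oc2=O)ccc1O`, which in this assay gives 1460 nM. The step of a 1.5-fold lower number from compound 1 to compound 2 (0.18 log units; within the scatter) therefore stays within the scatter. Compound 3, with the structure `CC(C)=CCc1cc(C(=O)Nc2cc3ccc(OCCCN(C)C4CCCCC4)c(C)c3oc2=O)ccc1O`, gives 1080 nM in this assay, and the step of a 2.0-fold lower number from compound 1 to compound 3 (0.31 log units; beyond the scatter) is the only one of the three that reaches beyond the scatter. The unmeasured compound 4 has the structure `CC(C)=CCc1cc(C(=O)Nc2cc3ccc(OCCCNCc4ccccc4)c(C)c3oc2=O)ccc1O` and differs from compound 1 in one place: benzylamino in place of ethyl(methyl)amino on a saturated chain carbon, three bonds along the chain from an oxygen on an aromatic ring. Both measured steps alter the same amine at the same place along the chain, and the larger of them, with a ring entering, was modest; the one that added a hydrogen-bond donor was within the scatter. The account accordingly expects for compound 4 a small step, a 1.7-fold lower number from compound 1 to compound 4 (0.23 log units; within the scatter), and estimates its value in this assay at 1300 nM, within a range from 600 nM to 2800 nM.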

Compound 4, half-maximal inhibitory concentration: 910 nM
The estimate for compound 4 lay 1.4-fold (0.15 log units) above the measured number; measured number inside the range.
By their numbers in this assay, from the lowest: compounds 4, 3, 2 and 1 (each within the scatter of the next, the first and the last beyond it).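

With benzylamino, a second replacement of ethyl(methyl)amino at this place on the chain passes the scatter in this assay: a 2.4-fold lower number from compound 1 to compound 4 (0.38 log units; beyond the scatter) is a modest step, and a ring carried one carbon away from the amine nitrogen does as much here as the cyclohexyl of compound 3. The new group does not separate from the earlier replacements, since a 1.2-fold lower number from compound 3 to compound 4 (0.07 log units; within the scatter) and a 1.6-fold lower number from compound 2 to compound 4 (0.21 log units; within the scatter) both stay within the scatter, so phenyl and carbamoyl on the saturated chain carbon bound to the amine nitrogen cannot be told apart. Only compound 1 stands apart, and only from compounds 3 and 4.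

Going by these compounds, whether a phenethylamino group, a benzyl(methyl)amino group or a longer chain would take the number further remains open. Nothing at hand explains why these amines give such similar numbers.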